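Working notes on a small cytotoxicity series

This account rests on a few compounds, and the source may have more. Where it says the series, first, only, none or still open, it means among the compounds named here.

Measured so far:
compound 1 `COc1cc(-c2cc(/C=C/C(=O)c3ccc(N)cc3)[nH]n2)cc(OC)c1OC`, 102%
compound 2 `COc1ccc(-c2cc(/C=C/C(=O)c3ccc(OC)c(OC)c3)[nH]n2)cc1`, 100%
compound 3 `COc1cc(C(=O)/C=C/c2cc(-c3cc(OC)c(OC)c(OC)c3)n[nH]2)cc(OC)c1OC`, 100%

In a functional assay on NCI-H23 cells (Homo sapiens) for cytotoxicity, read by sulforhodamine B assay, with a stated time of 48 h, tested at 0.01 uM (on this read-out higher numbers stand for a weaker effect at the one concentration tested and lower numbers for a stronger effect), compound 1 gives 102%, the highest of the three numbers. Compound 2 gives 100% and compound 3 gives 100%; both lie within the scatter of the number for compound 1, so the three measured compounds cannot be told apart. Going by the values given here, no step between measured compounds that differ in one place is available.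

Compound 4 `COc1cc(-c2cc(/C=C/C(=O)c3ccc(F)c(F)c3)[nH]n2)cc(OC)c1OC` differs from compound 1 in one place: 3,4-difluorophenyl in place of 4-aminophenyl on a carbonyl carbon. Since every measured value in this assay sits at the same level, no step beyond the scatter is expected in this assay for this change. Compound 4 is expected to give 100%, in a range from 88% to 110%. The estimated step is a number 2 percentage points lower from compound 1 to compound 4 (within the scatter), nothing beyond the scatter.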

Compound 4, a percentage reported as activity, at one concentration (the size of the read-out at that concentration, not a potency): 95%
For compound 4 the middle estimate is 5 percentage points above the measured one; measured number inside the range.
By their numbers in this assay, from the lowest: compounds 4, 2, 3 and 1 (each within the scatter of the next).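

In this assay, going by these compounds alone, 3,4-difluorophenyl in place of 4-aminophenyl on a carbonyl carbon gives the first readable step at this position, a number 7 percentage points lower from compound 1 to compound 4 (within the scatter) and nothing beyond the scatter. At this single concentration, the read-out therefore tolerates replacing a group that has a hydrogen-bond donor and acceptor with one that has neither. Nothing available bears on why the read-out holds through this change.

Open, on these data alone, is whether a carboxylic acid or a dimethylamino group on the same carbonyl carbon would shift the number beyond the scatter. Also open, as far as these compounds go, is whether the core of compound 1 shows any clear effect at a higher concentration.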